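Swapping the Halogen-Bearing Ring on a Thromboxane Synthase Inhibitor

The source may report more compounds than this note shows. Statements on the series, on what has been measured and on what is new or still open speak of the compounds shown alone.

Three compounds share one core and differ only in the aromatic ring attached to its double-bonded chain carbon. Compound 1 `O=C(O)CCCC/C=C(/c1ccc(F)cc1)c1cccnc1` carries a 4-fluorophenyl ring there, and in an assay (Equus caballus) for inhibition of Thromboxane-A synthase (Homo sapiens), using microsomes (a higher number here means a weaker inhibitor, a lower number a stronger inhibitor), compound 1 gives 83 nM. That is the highest of the three numbers, but only just: compound 2 `COc1ccc(/C(=C/CCCCC(=O)O)c2cccnc2)cc1`, with a methoxy group in place of the fluorine, gives 80 nM, and compound 3 `O=C(O)CCCC/C=C(/c1cccnc1)c1ccsc1`, with a different ring in place of the 4-fluorophenyl, gives 62 nM. Among the compounds with values here, the step of a 1.0-fold lower number from compound 1 to compound 2 (0.02 log units; within the scatter) lies within the scatter, and the values of compound 1 and compound 3 are likewise within the scatter of each other, so none of the measured changes at this ring moved the read-out beyond noise.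

Compound 4 `O=C(O)CCCC/C=C(\c1cccnc1)c1ccccc1Br` has not been measured. It differs from compound 1 by 2-bromophenyl in place of 4-fluorophenyl on a double-bonded chain carbon bound to an aromatic carbon and a double-bonded chain carbon. Within the data shown here, no measured step involves a 2-bromophenyl group, so the only guide is that both changes at this ring seen so far left the number essentially unchanged. The step is therefore expected to be small, in either direction, with a 1.2-fold higher number from compound 1 to compound 4 (0.08 log units; within the scatter) as the expected outcome. For compound 4 in this assay the estimate is 100 nM, within a range from 40 nM to 250 nM.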

Compound 4, half-maximal inhibitory concentration: 130 nM
Compound 4: the middle estimate sits 1.3-fold (0.11 log units) below what was measured; the measured number falls inside the stated range.
By their numbers in this assay, from the lowest: compounds 3, 2, 1 and 4 (each within the scatter of the next, the first and the last beyond it).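

Replacing 4-fluorophenyl with 2-bromophenyl gives a 1.6-fold higher number from compound 1 to compound 4 (0.19 log units; within the scatter), so this change, which swaps the halogen and also alters where it sits on the ring, stays within the usual scatter of this assay. What is new is the spread across the set: compound 3 gives 62 nM and compound 4 gives 130 nM, the first pair changed at this position whose numbers lie beyond the scatter of each other, even though each compound in the order from compound 3 through compound 2 and compound 1 to compound 4 lies within the scatter of the next. Nothing measured here offers an explanation for this spread or for the step from compound 1 to compound 4.

The compounds shown leave open whether the identity of the halogen or its place on the ring has any bearing on the read-out, as the two change together in compound 4. Also open, from the compounds shown here alone, is how the read-out responds to a quite different group on this phenyl ring, such as an amine, a nitrile or a carboxylic acid.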